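Isopropoxy in place of allyloxy on an amidoxime-bearing indole

The compounds below may be only part of what the source reports. "The series", "measured", "known", "first", "only" and "open" are said of these compounds alone.

Two compounds of a shared core carrying a substituted amidine-type group have been measured in a physicochemical assay for solubility, in phosphate buffer, at pH 7.4; on this read-out lower numbers stand for lower solubility and higher numbers for higher solubility. Compound 1 `CCONC(=N)c1ccc2[nH]c(-c3cccc(-c4ccccc4O)c3O)cc2c1` gives 43000 nM in this assay . Compound 2 `C=CCO/N=C(/N)c1ccc2[nH]c(-c3cccc(-c4ccccc4O)c3O)cc2c1` gives 24000 nM in this assay . Going by the values given here, on these two numbers compound 2 sits within the scatter of compound 1, and the only step known, a 1.8-fold lower number from compound 1 to compound 2 (0.25 log units; within the scatter), is itself within the scatter, so neither compound can be called more or less soluble than the other.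

Compound 3 `CC(C)ONC(=N)c1ccc2[nH]c(-c3cccc(-c4ccccc4O)c3O)cc2c1` is the next member of the series. It differs from compound 2 by a group of 7 heavy atoms (4 carbon, 2 nitrogen, 1 oxygen; no ring) in place of a group of 7 heavy atoms (4 carbon, 2 nitrogen, 1 oxygen; no ring), on an aromatic carbon. Among the compounds with values here, the one measured step, an exchange of a similar group of seven heavy atoms at the same aromatic carbon, moved this assay by a 1.8-fold lower number from compound 1 to compound 2 (0.25 log units; within the scatter), which is no more than repeat measurements drift. The change into compound 3 is of the same kind and size, so no step beyond the scatter is expected in this assay . Compound 3 is therefore estimated at 30000 nM, with a range from 12000 nM to 75000 nM, which means a step of a 1.3-fold higher number from compound 2 to compound 3 (0.10 log units; within the scatter) that is expected to stay within the scatter.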

Compound 3, solubility: 25000 nM
The estimate for compound 3 lay 1.2-fold (0.08 log units) above the measured number; the range from low to high includes it.
By their numbers in this assay, from the lowest: compounds 2, 3 and 1 (each within the scatter of the next).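

In this assay, replacing a group with 2 double bonds outside aromatic rings and 1 hydrogen-bond donor by one with 1 double bond outside aromatic rings and 2 hydrogen-bond donors, at the same heavy-atom count on the aromatic carbon of the six-membered ring, gave a 1.0-fold higher number from compound 2 to compound 3 (0.02 log units; within the scatter). The comparison with the ethoxy-bearing compound adds a second change within the same chain, methyl in place of hydrogen on a saturated chain carbon, and this gave a 1.7-fold lower number from compound 1 to compound 3 (0.24 log units; within the scatter), so all three chains now stand unseparated at this position, as neither the unsaturation nor the branching produced a step beyond the scatter. No independent evidence bears on this result.

What a carboxylic acid, an amine or a much longer chain such as octyloxy would do at this aromatic carbon in this assay remains open, since the three groups shown are all short oxygen-linked chains of similar size. Also open, as far as these compounds go, is whether the same exchanges would stay within the scatter on a core lacking the two hydroxyl groups of the shared core.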